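Removing a methyl from the aryl ether of a pyrazole urea

A few compounds are considered here, and "the series" means these few. Any claim that something is new, unique, unknown or untested is made for them only; others in the source may bear on it.

Three compounds share a core built from a pyrazole carrying a pyridyl group and a urea-linked aniline. Compound 2 `COc1cc(-c2nn(-c3cccc(NC(=O)Nc4ccc(Cl)c(Cl)c4)c3)cc2-c2ccncc2)ccc1Cl` is the only one with a numerical result: in a functional assay on OVCAR-8 cells (Homo sapiens) for inhibition, read by sulforhodamine B assay, with a stated time of 48 h (on this read-out lower numbers stand for stronger inhibition of growth and higher numbers for weaker inhibition of growth), compound 2 gives 3610 nM. Compound 1 `O=C(Nc1cccc(-n2cc(-c3ccncc3)c(-c3ccc(Cl)c(O)c3)n2)c1)Nc1cccc(C(F)(F)F)c1`, which carries a trifluoromethyl on its urea partner and a hydroxy instead of the methoxy, reaches only a limit of the assay, giving > 32500 nM in this assay; this is recorded as the limit of > 32500 nM in this assay, at which 1 of the 2 values shown sits. Compound 3 `O=C(Nc1cccc(-n2cc(-c3ccncc3)c(-c3ccc(Cl)c(O)c3)n2)c1)Nc1ccc(Cl)c(Cl)c1`, not yet measured, differs from compound 2 in one place: hydrogen in place of methyl on an oxygen on an aromatic ring, so that the methoxy becomes a hydroxy. Among the measured compounds shown here, since no measured pair shows this change alone, the direction is uncertain, but a weakening step beyond the usual scatter is expected, a 2.5-fold higher number from compound 2 to compound 3 (0.40 log units; beyond the scatter), because compound 1, which also bears the hydroxy, gives > 32500 nM. Compound 3 is therefore estimated at 9000 nM in this assay, with a plausible range from 2500 nM to 32500 nM.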

Compound 3, concentration for total growth inhibition: > 32500 nM
Compound 3 ended at the assay's limit (the forecaster's own chance of this, stated with the estimate: 30%); middle value at least 3.6-fold (0.55 log units) away from the limit.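

In this assay, among the compounds shown here, this is the first pair in which the change from methoxy to hydroxy stands alone, on an oxygen on an aromatic ring, and it gives a step beyond the usual scatter: an at least 9.0-fold higher number from compound 2 to compound 3 (0.95 log units; beyond the scatter). On this pair, then, the methyl on that oxygen matters for growth inhibition, and replacing it with hydrogen leaves no measurable number in this assay. With the hydroxy in place, the step between the 3-(trifluoromethyl)phenyl and 3,4-dichlorophenyl urea partners of compound 1 and compound 3 cannot be read, as both compounds rest at a limit of the assay, so neither partner can be ranked: the limit of > 32500 nM in this assay, at which 2 of the 3 values shown sit.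

The compounds shown leave open how a longer chain on that oxygen, such as an ethoxy, or an amine in place of the hydroxy would read in this assay. They also leave open whether the same change would matter with 3-(trifluoromethyl)phenyl as the urea partner, as only the 3,4-dichlorophenyl pair shows the methoxy and the hydroxy side by side.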